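Carbamate for Carbonyl Azide on a Methoxy Quinoxaline Dioxide

The compounds below may be only part of what the source reports. "The series", "measured", "known", "first", "only" and "open" are said of these compounds alone.

Compound 1, `Cc1c(C(=O)N=[N+]=[N-])[n+]([O-])c2cc(Cl)ccc2[n+]1[O-]`: > 100 ug/mL
Compound 2, `COc1ccc2c(c1)[n+]([O-])c(C(=O)N=[N+]=[N-])c(C)[n+]2[O-]`: 12.5 ug/mL

Of the compounds shown here, two have been measured in a functional assay on Ehrlich cells (Mus musculus) for cytotoxicity, read by trypan blue exclusion; on this read-out lower numbers stand for stronger inhibition and higher numbers for weaker inhibition. Compound 1 reaches only a limit of the assay, > 100 ug/mL, and no number. Going by the values given here, compound 2 gives 12.5 ug/mL, the only actual number in this assay, so compound 2 stands as the single anchor for any estimate. Among the compounds with values here, the step of an at least 8.0-fold lower number from compound 1 to compound 2 (0.90 log units; beyond the scatter) is the one measured change, and it concerns the chloro-to-methoxy exchange; the size of that step is known only as a bound, because compound 1 sits at the limit of > 100 ug/mL in this assay, at which 1 of the 2 values shown sits.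

Compound 3, `COc1ccc2c(c1)[n+]([O-])c(NC(=O)OC(C)C)c(C)[n+]2[O-]`, is not yet measured. It differs from compound 2 by a group of 7 heavy atoms (4 carbon, 1 nitrogen, 2 oxygen; no ring) in place of a group of 5 heavy atoms (1 carbon, 3 nitrogen, 1 oxygen; no ring), on an aromatic carbon, the (isopropoxycarbonyl)amino group entering next to the ring nitrogen and ortho to a methyl group. Within the data shown here, no measured step touches this position, so the change from compound 2 to compound 3 has no direct precedent here.

With nothing to guide direction, compound 3 is expected to land near compound 2, and the step of a 1.6-fold higher number from compound 2 to compound 3 (0.20 log units; within the scatter) is estimated to stay within the scatter. Compound 3 is therefore estimated at 20 ug/mL, in a range from 6 ug/mL to 80 ug/mL.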

Compound 3, half-maximal inhibitory concentration: > 100 ug/mL
Compound 3 ended at the assay's limit; the forecaster's own chance of this, stated with the estimate: 25%; at least 5.0-fold (0.69 log units) between middle value and limit.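

At this position, next to the ring nitrogen and ortho to a methyl group, the group is not interchangeable on the shared methoxy core: (isopropoxycarbonyl)amino in place of the carbonyl azide gives an at least 8.0-fold higher number from compound 2 to compound 3 (0.90 log units; beyond the scatter) in this assay. Compound 3 reaches only a limit of the assay, > 100 ug/mL, and no number. Compound 2 therefore remains the only compound with an actual value, and both measured steps now connect it to a limit, with their true size unknown because each of them ends there: the limit of > 100 ug/mL in this assay, at which 2 of the 3 values shown sit.

What the compounds shown leave open is whether the difference follows from the carbonyl azide leaving or from the (isopropoxycarbonyl)amino group entering, since only these two groups are seen at this position on the methoxy core. A free amine, a simple acetamide or a carboxylic acid at the same place, or a shorter methoxycarbonylamino chain, would show how much activity in this assay is tied to the carbonyl azide itself and how much of it a carbamate of another size could keep.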